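The source may report more compounds than this note shows. Statements on the series, on what has been measured and on what is new or still open speak of the compounds shown alone.

Measured compounds:
Compound 1 `Oc1ccc(CNc2cc(C(F)(F)F)cc3[nH]ncc23)cc1`: 81%
Compound 2 `O=[N+]([O-])c1ccccc1CNc1cccc2[nH]ncc12`: 65%

In an assay for inhibition of Indoleamine 2,3-dioxygenase 1 (Homo sapiens), with stated times of 10 min and 60 min, tested at 100 uM (a lower number here means a weaker effect, a higher number a stronger effect of the compound at the concentration tested), compound 1 gives 81% and compound 2 gives 65%. Compound 2 thus has the lower of the two numbers, with compound 1 standing higher by a gap beyond the usual scatter. Compound 3 `COC(=O)c1cc(NCc2ccccc2[N+](=O)[O-])c2cn[nH]c2c1` differs from compound 2 by methoxycarbonyl in place of hydrogen on an aromatic carbon. Among the compounds with values here, no measured pair shows the effect of adding a methoxycarbonyl, so in this assay the step of no change at the digits printed from compound 2 to compound 3 (within the scatter) is expected to be small, likely within the scatter. Compound 3 is therefore estimated at 65%, expected to fall between 40% and 85%.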

Compound 3, a percentage reported as inhibition, at one concentration (the size of the read-out at that concentration, not a potency): 47%
For compound 3 the middle estimate is 18 percentage points above the measured one; the measured number falls inside the stated range.
By their numbers in this assay, from the lowest: compound 3; then compound 2; then compound 1.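

In this assay, within the data shown here, methoxycarbonyl in place of hydrogen on this aromatic carbon brings a number 18 percentage points lower from compound 2 to compound 3 (beyond the scatter) and so gives the first reading of a change at this position. It shows that the read-out at the concentration tested is not indifferent to what sits here. No separate measurement bears on why the number falls. The compounds shown leave open whether this step belongs to methoxycarbonyl itself or would also appear with another group on the same carbon, such as a carboxylic acid or an amine.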